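The source may report more compounds than this note shows. Statements on the series, on what has been measured and on what is new or still open speak of the compounds shown alone.

Compound 1 `COc1cc(/C=C/C(=O)/C=C/c2cccc3ccccc23)ccc1OCc1cn(CCCOc2cc(=O)oc3ccccc23)nn1`: 64%
Compound 2 `COc1cc(/C=C/C(=O)/C=C/c2cccc3ccccc23)ccc1OCc1cn(CCCCOc2cc(=O)oc3ccccc23)nn1`: 50%

For the measured compounds named here, in a functional assay on COLO 205 cells (Homo sapiens) for inhibition, read by sulforhodamine B assay, with a stated time of 48 h, tested at 50 uM (on this read-out higher numbers stand for more inhibition of growth at the one concentration tested and lower numbers for less inhibition of growth), compound 1 gives 64%, the higher of the two numbers so far. Compound 2 gives 50%, a gap beyond the usual scatter. Compound 3 `COc1ccc(/C=C/C(=O)/C=C/c2ccc(OCc3cn(CCCOc4cc(=O)oc5ccccc45)nn3)c(OC)c2)cc1OC` has not yet been measured. It departs from compound 1 at one place: 3,4-dimethoxyphenyl in place of naphthalen-1-yl on a double-bonded chain carbon bound to a double-bonded chain carbon. That is, 3,4-dimethoxyphenyl stands in place of naphthalen-1-yl on a double-bonded chain carbon bound to a double-bonded chain carbon. Going by the values given here, no measured pair shows this exchange, so the data offer no direct guide to its size. In this assay only a slight fall, not beyond the scatter, is expected from the starting point of compound 1 at 64%. The estimated change is a number 4 percentage points lower from compound 1 to compound 3 (within the scatter). The expected value for compound 3 is 60%, with an estimated range of 42% to 78%.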

Compound 3, percent growth inhibition at one concentration: 65%
Beside the measured number, compound 3's estimate is 5 percentage points below it, within the range that was stated.
By their numbers in this assay, from the lowest: compound 2; then compounds 1 and 3 (each within the scatter of the next).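

In this assay the exchange of naphthalen-1-yl for 3,4-dimethoxyphenyl on a double-bonded chain carbon bound to a double-bonded chain carbon gives a number 1 percentage points higher from compound 1 to compound 3 (within the scatter) and so shows that this position accepts either group with no change that can be told from the scatter. Both groups count 10 heavy atoms, but the one that enters has a single six-membered aromatic ring and carries hydrogen-bond acceptors, and these differences leave no mark on this one-concentration read-out. No measurement shown bears on why the two groups read alike.

On these data alone, it remains open whether a group carrying an amine, such as 4-(dimethylamino)phenyl, or one carrying a carboxylic acid would hold the number at this position. As far as these compounds go, it is also open whether 3,4-dimethoxyphenyl would behave the same way on the longer chain of compound 2.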